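A few compounds are considered here, and "the series" means these few. Any claim that something is new, unique, unknown or untested is made for them only; others in the source may bear on it.

Compound 1 `CCN(CC)c1cc2[nH]c(C3CCCCC3)nc2cc1NC(=O)c1cnccn1` sits at the limit of an ADME assay on Vero cells (Chlorocebus sabaeus) for cytotoxicity, read by resazurin assay, with a stated time of 3 days; on this read-out higher numbers stand for weaker inhibition and lower numbers for stronger inhibition: in this assay compound 1 gives > 100 ug/mL, a limit of the assay rather than a number. Compound 2 `Cc1ccc(C(=O)Nc2cc3nc(C4CCCCC4)[nH]c3cc2N2CCCC2)cc1` gives > 100 ug/mL, also a limit. Compound 3 `CCCOCC(=O)Nc1cc2nc(C3CCCCC3)[nH]c2cc1N1CCCC1` gives > 100 ug/mL, again a limit. Within the data shown here, the single measured one-place step, a step that the two limits leave unreadable from compound 2 to compound 3, cannot be read, since both of its ends sit at the limit of > 100 ug/mL in this assay, at which 3 of the 3 values shown sit. Compound 4 `CCOc1ccc(C(=O)Nc2cc3nc(C4CCCCC4)[nH]c3cc2N(CC)CC)cc1` differs from compound 1 by 4-ethoxyphenyl in place of pyrazin-2-yl on a carbonyl carbon. Among the measured compounds shown here, no measured step reads on this change; every value shown is a limit, so no step beyond the scatter is expected in this assay. Compound 4 is therefore expected to give 150 ug/mL, in the range 60 ug/mL to 400 ug/mL, most probably reported once more as a limit. The expected step that the limit leaves unreadable from compound 1 to compound 4 amounts to no change.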

Compound 4, half-maximal inhibitory concentration: > 100 ug/mL
Compound 4 was reported as a limit; the forecaster's own chance of this, stated with the estimate: 80%; the middle value lies beyond the limit too.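

In this assay compound 4 gives > 100 ug/mL, a limit rather than a number. No step can be read from compound 1 to compound 4, since both ends sit at a limit: the limit of > 100 ug/mL in this assay, at which 4 of the 4 values shown sit.

The compounds shown leave open whether any change on the carbonyl carbon shifts cytotoxicity at all.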